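This account rests on a few compounds, and the source may have more. Where it says the series, first, only, none or still open, it means among the compounds named here.

Measured in an assay on CHO cells for agonist activity at G protein-coupled receptor GPR35 (Rattus norvegicus), read by a beta-galactosidase reporter and beta-arrestin recruitment, with a stated time of 90 min; a higher number here means that more compound is needed for the effect, a lower number that less compound is needed:
compound 1 `CCOc1ccc(C(=O)Nc2cc(Br)cc3c(=O)cc(C(=O)O)oc23)cc1` gives 1360 nM
compound 2 `COc1ccc(C(=O)Nc2cc(Cl)cc3c(=O)cc(C(=O)O)oc23)cc1` gives 1830 nM
compound 3 `O=C(Nc1cc(Cl)cc2c(=O)cc(C(=O)O)oc12)c1ccc([N+](=O)[O-])cc1` gives 3140 nM

Compound 1 has the lowest number of the three; its gap to compound 2 lies within the scatter, its gap to compound 3 beyond it. Compound 4 `O=C(Nc1cc(Br)cc2c(=O)cc(C(=O)O)oc12)c1ccc(Cl)c(Cl)c1` differs from compound 1 in one place: 3,4-dichlorophenyl in place of 4-ethoxyphenyl on a carbonyl carbon. Among the measured compounds shown here, the only measured step at the same place is a 1.7-fold higher number from compound 2 to compound 3 (0.23 log units; within the scatter), which stayed within the scatter. For the measured compounds named here, no measured compound carries a 3,4-dichlorophenyl, so the expectation rests on that step alone: a small shift in this assay, if any, toward a higher number. Compound 4 is therefore estimated at 1800 nM, with a range of 700 nM to 4500 nM. The step expected from this is a 1.3-fold higher number from compound 1 to compound 4 (0.12 log units; within the scatter).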

Compound 4, half-maximal effective concentration: 3250 nM
Compound 4: the middle estimate sits 1.8-fold (0.26 log units) below what was measured; low and high end bracket the measured number.
By their numbers in this assay, from the lowest: compounds 1, 2, 3 and 4 (each within the scatter of the next, the first and the last beyond it).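

In this assay, 3,4-dichlorophenyl in place of 4-ethoxyphenyl on a carbonyl carbon gives a 2.4-fold higher number from compound 1 to compound 4 (0.38 log units; beyond the scatter), the only change shown at this place that lies beyond the scatter, whereas a 1.7-fold higher number from compound 2 to compound 3 (0.23 log units; within the scatter) stays within it. The group on this carbon can therefore move the number, though only modestly. No measurement at hand explains this shift.

On these data alone, it remains open whether the rise follows from the chlorines entering or from the ethoxy leaving. An unsubstituted phenyl, a 4-chlorophenyl or a 4-propoxyphenyl at this carbon would help separate the two.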